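The compounds below may be only part of what the source reports. "The series", "measured", "known", "first", "only" and "open" are said of these compounds alone.

Values in an ADME assay on Vero cells (Chlorocebus sabaeus) for cytotoxicity (on this read-out lower numbers stand for higher toxicity in this test and higher numbers for lower toxicity in this test), for the measured compounds, each one a limit of the assay and not a number:

Compound 1 `COCCNc1cccn2c(-c3ccnc(NC4CCCC4)n3)c(-c3ccc(F)cc3)nc12` gives > 40000 nM as a limit
Compound 2 `Fc1ccc(-c2nc3c(C4CCCC4)cccn3c2-c2ccnc(NC3CCCC3)n2)cc1` gives > 40000 nM as a limit
Compound 3 `Fc1ccc(-c2nc3ccc(NC4CCCC4)cn3c2-c2ccnc(NC3CCCC3)n2)cc1` gives > 40000 nM as a limit

Compound 3 stands only at a limit in this assay and no number places it. The measured set shows the limit of > 40000 nM in this assay, at which 3 of the 3 values shown sit, and nothing more. Within the data shown here, compound 4 `Fc1ccc(-c2nc3ccccn3c2-c2ccnc(NC3CCCC3)n2)cc1` differs from compound 3 by hydrogen in place of cyclopentylamino on an aromatic carbon in the one change of hydrogen in place of cyclopentylamino on an aromatic carbon. Among the measured compounds shown here, the only measured step is a step that the two limits leave unreadable from compound 1 to compound 2 and it gives no size to carry over, since it concerns another exchange. No step beyond the scatter can therefore be expected from the data in this assay in either direction. The expectation rests on compound 3, whose value > 40000 nM is a limit. The expected step is a number no higher from compound 3 to compound 4 (the limit leaves the size open) and no real change is expected in it. Compound 4 is estimated at 40000 nM with an expected range from 20000 nM to 80000 nM and most likely only a limit will be reported.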

Compound 4, half-maximal cytotoxic concentration: > 40000 nM
Compound 4: a limit, no number; the forecaster's own chance of this, stated with the estimate: 85%; the middle value sits exactly at the limit.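

In this assay compound 4 gives > 40000 nM, which is a limit. No step from compound 1, compound 2 or compound 3 to compound 4 can be read, because all four values are limits: the limit of > 40000 nM in this assay, at which 4 of the 4 values shown sit.

The compounds shown leave open where any of them would begin to harm these cells, and whether any of the exchanged groups alters that.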